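The source may report more compounds than this note shows. Statements on the series, on what has been measured and on what is new or still open speak of the compounds shown alone.

Three compounds have been examined in an assay for inhibition of Nicotinamide phosphoribosyltransferase (Homo sapiens), read by mass spectrometry, with stated times of 15 min and 30 min; a higher number here means a weaker inhibitor, a lower number a stronger inhibitor. Compound 1 `O=C(NCc1ccc(S(=O)(=O)c2ccc(F)c(F)c2)cc1)c1cc2cnccc2[nH]1` gives 10 nM, compound 2 `O=C(NCc1ccc(S(=O)(=O)N2CCCCC2)cc1)c1cc2ccncc2[nH]1` gives 1000 nM, and compound 3 `O=C(NCc1ccc(S(=O)(=O)c2ccccc2)cc1)c1cc2ccncc2s1` gives 7 nM. Compound 3 shows the lowest number of the three, but its gap to compound 1 is within the usual scatter, so the two cannot be told apart; only compound 2 stands clearly apart, with a much higher number.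

Compound 4 `O=C(NCc1ccc(S(=O)(=O)c2ccccc2)cc1)c1cn2ccnc2cn1` keeps everything of compound 3 except the group attached to the carbonyl carbon: a group of 9 heavy atoms (6 carbon, 3 nitrogen; one five-membered aromatic ring with 2 hetero atoms, one six-membered aromatic ring with 2 hetero atoms) in place of a group of 9 heavy atoms (7 carbon, 1 nitrogen, 1 sulfur; one five-membered aromatic ring with 1 hetero atom, one six-membered aromatic ring with 1 hetero atom), on a carbonyl carbon. Among the compounds with values here, no pair among the measured compounds shows this change, so its effect cannot be read from a measured step. Replacing one aromatic bicycle with another of the same size, in the part of the molecule that sits on the carbonyl, is a change that could go either way; a modest loss is expected here, from compound 3 to compound 4 in this assay, of about a 4.3-fold higher number from compound 3 to compound 4 (0.63 log units; beyond the scatter). Compound 4 is therefore estimated at 30 nM, with a likely range from 7 nM to 150 nM.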

Compound 4, half-maximal inhibitory concentration: 150 nM
Beside the measured number, compound 4's estimate is 5.0-fold (0.70 log units) below it, and the stated range covers the measured number.
By their numbers in this assay, from the lowest: compounds 3 and 1 (each within the scatter of the next); then compound 4; then compound 2.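

In this assay, exchanging one aromatic group of 9 heavy atoms for another on the carbonyl carbon gives a 21-fold higher number from compound 3 to compound 4 (1.33 log units; beyond the scatter). Within the data shown here, this is the first single-place comparison, and it shows that this position is sensitive to the make-up of the group even when the ring sizes and the heavy-atom count stay the same: the group that enters has nitrogen in place of the sulfur and one carbon of the group that leaves. Nothing measured here explains why the number rises.

Among these compounds, with only this one step, the effect of losing the sulfur cannot be separated from that of adding nitrogen, and steps involving compound 1 or compound 2 cannot be read. Going by these compounds, it also remains open how a methoxy group or an amine on the group at this position would affect the number.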